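This account rests on a few compounds, and the source may have more. Where it says the series, first, only, none or still open, it means among the compounds named here.

Working notes on the series.

Compound 1 `[O-]c1on[n+](-c2ccc(Cc3ccc(-[n+]4noc([O-])c4CN4CCN(c5ccccc5)CC4)cc3)cc2)c1CN1CCN(c2ccccc2)CC1` carries two copies of the shared core. In an ADME assay on HEL cells (Homo sapiens) for cytotoxicity (a lower number here means that less compound is tolerated, a higher number that more compound is tolerated), compound 1 gives >= 20 ug/mL, which is a limit of the assay and not a number. Compound 2 `Cc1ccc(-[n+]2noc([O-])c2CN2CCN(c3cccc(Cl)c3)CC2)cc1` holds one copy of the core. In this assay, among the measured compounds shown here, compound 2 gives 100 ug/mL, the only number so far. The other value, that of compound 1, is a limit of the assay: the limit of >= 20 ug/mL in this assay, at which 1 of the 2 values shown sits. Compound 3 `Cc1ccc(-[n+]2noc([O-])c2CN2CCN(C)CC2)cc1` is next to be measured. Its change from compound 2: methyl in place of 3-chlorophenyl on an amine nitrogen in a ring. For the measured compounds named here, no measured step bears on this exchange, so the size of the effect rests on expectation alone. For compound 3 a small rise in tolerated concentration is expected, of about a 1.5-fold higher number from compound 2 to compound 3 (0.18 log units; within the scatter), though a result within the scatter of compound 2 is also plausible. For compound 3 the estimate is therefore 150 ug/mL, with a range from 60 ug/mL to 400 ug/mL.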

Compound 3, minimum cytotoxic concentration: 100 ug/mL
Compound 3: the middle estimate sits 1.5-fold (0.18 log units) above what was measured; the range from low to high includes it.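

At this position, methyl in place of 3-chlorophenyl gives no change at the digits printed from compound 2 to compound 3 (within the scatter) in this assay. Among the compounds shown here, this is the first measured reading of any exchange on the amine nitrogen in a ring, and it replaces expectation with a direct comparison. For this pair, the tolerated concentration is the same within the scatter whether that nitrogen carries a six-membered aromatic ring of carbon only, with its chlorine, or a single carbon, although one pair cannot establish a trend across the series.

From the compounds shown here alone, whether a carboxylic acid or a longer chain on the same nitrogen would stay level with compound 3 remains open. Compound 1 stays outside this comparison, as its value is a limit of the assay and not a number: the limit of >= 20 ug/mL in this assay, at which 1 of the 3 values shown sits.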